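Removing One Methoxy Group: Expected Cytotoxicity of Compound 4

A few compounds are considered here, and "the series" means these few. Any claim that something is new, unique, unknown or untested is made for them only; others in the source may bear on it.

Measured so far in a functional assay on MOLT-4 cells (Homo sapiens) for cytotoxicity, read by sulforhodamine B assay, with a stated time of 48 h, tested at 100 uM; a higher number here means a weaker effect of the compound at the concentration tested, a lower number a stronger effect:
compound 1, `COc1cc(-c2cc(/C=C/C(=O)c3ccc(N)cc3)[nH]n2)cc(OC)c1OC`, gives -20%
compound 2, `COc1ccc(-c2cc(/C=C/C(=O)c3ccc(OC)c(OC)c3)[nH]n2)cc1`, gives -33%
compound 3, `COc1cc(-c2cc(/C=C/C(=O)c3ccc(Cl)c(Cl)c3)[nH]n2)cc(OC)c1OC`, gives -15%

Compound 1 stands second highest of these three numbers. Compound 3 lies closest to it, with a step of a number 5 percentage points higher from compound 1 to compound 3 (within the scatter), so no order between compound 1 and compound 3 can be read. Compound 2 lies furthest away, and its value is lower than that of compound 1 by more than the scatter.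

Compound 4, `COc1ccc(-c2cc(/C=C/C(=O)c3ccc(N)cc3)[nH]n2)cc1OC`, differs from compound 1 by hydrogen in place of methoxy on an aromatic carbon. For the measured compounds named here, the only single-place step that has been measured, a number 5 percentage points higher from compound 1 to compound 3 (within the scatter), concerns the group on the carbonyl carbon, a different part of the shared core, and stays within the scatter. Going by the values given here, no measured step alters the ring that carries the methoxy groups. Compound 2 also differs from compound 1 at that ring, but in more than one place at once, so its value cannot be tied to the loss of one methoxy group alone. Among the compounds with values here, with no step that bears directly on the change, the expected step from compound 1 to compound 4 in this assay is no change at the digits printed from compound 1 to compound 4 (within the scatter), that is, no change beyond the scatter. For compound 4 the estimated value is therefore -20%, expected to fall between -38% and -2%.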

Compound 4, a percentage reported as activity, at one concentration (the size of the read-out at that concentration, not a potency): -22%
Estimate against measurement, compound 4: 2 percentage points above, and the stated range covers the measured number.
By their numbers in this assay, from the lowest: compound 2; then compounds 4, 1 and 3 (each within the scatter of the next).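

In this assay, putting hydrogen in place of methoxy on this aromatic carbon, which is ortho to a methoxy group and meta to a large group, gives a number 2 percentage points lower from compound 1 to compound 4 (within the scatter) and so leaves the read-out unchanged beyond the scatter. For the compounds shown here, this is the first single-place step at the ring carrying the methoxy groups; compound 2 differs from compound 1 in more than one place, and the step to compound 3 concerns the group on the carbonyl carbon, so neither could show what this one methoxy group alone contributes. Nothing at hand accounts for this lack of a clear change, and the result itself describes only the size of the step.

From the compounds shown here alone, it remains open whether a different group at this place, such as a hydroxy group, an ethoxy group or a fluorine atom, would also stay within the scatter. Going by these compounds, it is equally open whether the same loss of a methoxy group would give a similar step with the 3,4-dichlorophenyl group of compound 3 on the carbonyl carbon.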